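Trimming a biaryl to a chloro on a sulfonamide core

A few compounds are considered here, and "the series" means these few. Any claim that something is new, unique, unknown or untested is made for them only; others in the source may bear on it.

Compound 1 `COc1ccc(-c2cccc(S(=O)(=O)N3CCC(N4CCC(C)CC4)CC3)c2)cc1` gives 23 nM in a functional assay on DLD-1 cells (Homo sapiens) for antiproliferative activity, read by CellTiter-Glo, with a stated time of 72 h; on this read-out higher numbers stand for weaker inhibition and lower numbers for stronger inhibition.
Compound 2 `CCCC(=O)N(Cc1ccccc1)C1CCN(S(=O)(=O)c2c(C)cc(C)cc2C)CC1` gives > 5000 nM in this assay, which is a limit of the assay rather than a number.
Compound 3 `CC1CCN(C2CCN(S(=O)(=O)c3ccccc3-c3ccc(C(F)(F)F)cc3)CC2)CC1` gives 122 nM in this assay.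

Of the two compounds with a numerical value, compound 1 stands lowest, and the gap to compound 3 lies beyond the usual scatter. Compound 2 only reaches the limit of this assay. The account now turns to compound 4 `CC1CCN(C2CCN(S(=O)(=O)c3cccc(Cl)c3)CC2)CC1`, which has not yet been measured in this assay. Relative to compound 1, the change is chloro in place of 4-methoxyphenyl on an aromatic carbon, with the chloro standing meta to a large group.

Within the data shown here, no pair of measured compounds differs in one place, so there is no measured step to lean on. The change removes a whole aromatic ring and replaces it with a single atom, which is a large reduction in size. On that basis, compound 4 is expected to sit higher than compound 1 in this assay, and the step of a 17-fold higher number from compound 1 to compound 4 (1.24 log units; beyond the scatter) is expected to lie beyond the scatter. The estimate for compound 4 in this assay is 400 nM, with a range from 80 nM to 2500 nM.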

Compound 4, half-maximal inhibitory concentration: > 5000 nM
Compound 4: a limit, no number; the forecaster's own chance of this, stated with the estimate: 15%; at least 12-fold (1.09 log units) between middle value and limit.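

Compound 4 reads > 5000 nM in this assay, and this value is a limit of the assay, not a number. Among these compounds, it gives the first step in which only one place changes, and this shows that the group on this aromatic carbon is not a matter of indifference: chloro in place of 4-methoxyphenyl gives an at least 210-fold higher number from compound 1 to compound 4 (2.33 log units; beyond the scatter), so the activity of compound 1 does not survive this trimming, and the true size of the step stays unknown beyond that bound. Compound 4 also shares this limit with another compound, so the assay does not rank the two: the limit of > 5000 nM in this assay, at which 2 of the 4 values shown sit.

The compounds shown do not separate the loss of the aromatic ring from the loss of the methoxy group, since both leave together in this one change, and a plain phenyl or a methoxy group alone on this carbon would tell these two apart. They also leave open whether anything smaller than 4-methoxyphenyl can hold the activity, for example a pyridine ring or a short chain such as ethyl.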